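Swapping the Oxetane Amine for a Ketone Ring

This account rests on a few compounds, and the source may have more. Where it says the series, first, only, none or still open, it means among the compounds named here.

Compound 3 `Cc1n[nH]c2nc(-c3ccc(NS(=O)(=O)c4cc(Cl)ccc4F)cc3)nc(OCC3(CN)COC3)c12` gives 1 nM in an assay for inhibition of serine/threonine-protein kinase Sgk1 (Homo sapiens), with stated times of 30 min and 60 min, in the presence of a further agent that is not named here (a higher number here means a weaker inhibitor, a lower number a stronger inhibitor), the lowest of the two numbers measured. Compound 2 `CCOc1nc(-c2ccc(NS(=O)(=O)c3cc(Cl)ccc3F)cc2)nc2[nH]nc(C)c12` gives 23 nM. Compound 1 `CN1CCC(NC(=O)c2cc(-c3ccc(NS(=O)(=O)c4cccc(Cl)c4Cl)cc3)nc3[nH]ncc23)C1` sits at a limit of the assay, < 1 nM, rather than at a number (the limit of < 1 nM in this assay, at which 1 of the 3 values shown sits). The step of a 23-fold lower number from compound 2 to compound 3 (1.36 log units; beyond the scatter) shows a large gain when the (3-(aminomethyl)oxetan-3-yl)methyl group replaced methyl on the ring oxygen. Compound 4 `Cc1n[nH]c2nc(-c3ccc(NS(=O)(=O)c4cc(Cl)ccc4F)cc3)nc(OC3CCC(=O)CC3)c12` differs from compound 3 by 4-oxocyclohexyl in place of (3-(aminomethyl)oxetan-3-yl)methyl on an oxygen on an aromatic ring. Since a 23-fold lower number from compound 2 to compound 3 (1.36 log units; beyond the scatter) was large and compound 4 keeps a group of comparable size on that oxygen but without the aminomethyl part, a number between those of compound 2 and compound 3 is expected. Compound 4 is therefore estimated at 8 nM, with a range of 2 nM to 30 nM, which is expected to mean an 8.0-fold higher number from compound 3 to compound 4 (0.90 log units; beyond the scatter).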

Compound 4, half-maximal inhibitory concentration: 5 nM
Estimate against measurement, compound 4: 1.6-fold (0.20 log units) above, and the stated range covers the measured number.
By their numbers in this assay, from the lowest: compound 3; then compound 4; then compound 2.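

A 4-oxocyclohexyl group on this oxygen still gives a stronger inhibitor than ethyl (a 4.6-fold lower number from compound 2 to compound 4 (0.66 log units; beyond the scatter)), so the gain at this position does not depend entirely on the aminomethyl group. Even so, replacing the (3-(aminomethyl)oxetan-3-yl)methyl group costs some of that gain (a 5.0-fold higher number from compound 3 to compound 4 (0.70 log units; beyond the scatter)). No measurement shown here explains either step. The compounds shown leave open whether the ketone itself contributes or the six-membered ring alone is enough. A plain cyclohexyl group, or a cyclohexyl ring carrying an amine in place of the ketone, would separate these possibilities.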